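A Side-Chain Exchange at Compound 3

The compounds below may be only part of what the source reports. "The series", "measured", "known", "first", "only" and "open" are said of these compounds alone.

Compound 1 (`COC(C)CO[C@H](CC=C(C)C)C1=CC(=O)c2c(O)ccc(O)c2C1=O`) in a functional assay on HeLa cells (Homo sapiens) for cytotoxicity, read by MTT assay (on this read-out lower numbers stand for stronger inhibition and higher numbers for weaker inhibition), gives 53400 nM
Compound 2 (`CC(=O)OC(C)CO[C@H](CC=C(C)C)C1=CC(=O)c2c(O)ccc(O)c2C1=O`) in this assay gives 40100 nM

Among the compounds with values here, compound 2 stands within the scatter of compound 1, its only measured neighbour. Within the data shown here, the one measured step (a 1.3-fold lower number from compound 1 to compound 2 (0.12 log units; within the scatter)) exchanged acetyl for methyl on an oxygen on a saturated carbon and stayed within the scatter. Compound 3 (`CCCC(C)(O)CC(=O)O[C@H](CC=C(C)C)C1=CC(=O)c2c(O)ccc(O)c2C1=O`) carries a larger exchange ((2-hydroxy-2-methylpentyl)carbonyl in place of 2-acetoxypropyl on an oxygen on a saturated carbon), with (2-hydroxy-2-methylpentyl)carbonyl in place of 2-acetoxypropyl. Among the measured compounds shown here, no measured step covers this exchange, so the earlier step offers only weak guidance. In this assay no shift beyond the scatter is therefore expected, though with wide uncertainty. The expected step is small (a 1.3-fold lower number from compound 2 to compound 3 (0.13 log units; within the scatter)). For compound 3 the estimated value is 30000 nM (expected range 8000 nM to 80000 nM).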

Compound 3, half-maximal inhibitory concentration: 72000 nM
The estimate for compound 3 lay 2.4-fold (0.38 log units) below the measured number, within the range that was stated.
By their numbers in this assay, from the lowest: compounds 2, 1 and 3 (each within the scatter of the next).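

In this assay, a larger exchange on the oxygen on a saturated carbon also stays within the scatter: (2-hydroxy-2-methylpentyl)carbonyl in place of 2-acetoxypropyl gives a small step (a 1.8-fold higher number from compound 2 to compound 3 (0.25 log units; within the scatter)), and the same group in place of 2-methoxypropyl gives another (a 1.3-fold higher number from compound 1 to compound 3 (0.13 log units; within the scatter)). The position has thus taken a group attached through its carbonyl and carrying a hydrogen-bond donor, with no shift beyond the scatter from either earlier compound. No measurement is available that could account for these numbers.

The compounds shown leave open whether an amine, a carboxylic acid or a phenyl ring on this oxygen would move the number beyond the scatter. They also do not separate the hydroxyl of the entering group from its pentyl chain, as both arrive in a single exchange.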